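Swapping Benzyl for 4-Methylphenyl on an Amide Nitrogen

This account rests on a few compounds, and the source may have more. Where it says the series, first, only, none or still open, it means among the compounds named here.

Among the measured compounds shown here, in an ADME assay on BEAS-2B cells (Homo sapiens) for cytotoxicity, read by fluorescence, with a stated time of 48 h (on this read-out higher numbers stand for lower toxicity in this test and lower numbers for higher toxicity in this test), compound 3 `Cc1ccoc1C(=O)N1CCCn2nc(C(=O)NCc3ccccc3)cc2C1` gives 50000 nM, the higher of the two numbers available so far. Compound 1 `O=C(Nc1ccccc1)c1cc2n(n1)CCCN(C(=O)c1occ3c1CCC3)C2` gives 10000 nM, a gap beyond the usual scatter, while compound 2 `O=C(Nc1ccccc1)c1cc2n(n1)CCCN(C(=O)c1ccncn1)C2` stands as "not determined" (no result reported), with no reported result. Compound 4 `Cc1ccc(NC(=O)c2cc3n(n2)CCCN(C(=O)c2occc2C)C3)cc1` has the same atoms as compound 3, joined differently, with 4-methylphenyl in place of benzyl on an amide-type nitrogen. For the measured compounds named here, no measured pair shows this change alone, so the evidence is thin. Compound 1, which has phenyl rather than benzyl on that nitrogen, stands at 10000 nM, so a downward move beyond the scatter is expected, a 3.3-fold lower number from compound 3 to compound 4 (0.52 log units; beyond the scatter). For compound 4 the estimated value is 15000 nM, with an expected range of 5000 nM to 50000 nM.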

Compound 4, half-maximal cytotoxic concentration: 30000 nM
Compound 4: middle estimate off by 2.0-fold (0.30 log units), on the low side; the range from low to high includes it.
By their numbers in this assay, from the lowest: compound 1; then compounds 4 and 3 (each within the scatter of the next).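

In this assay the change to 4-methylphenyl in place of benzyl on the amide-type nitrogen gives a 1.7-fold lower number from compound 3 to compound 4 (0.22 log units; within the scatter) and so no real separation between the two groups. Among the compounds shown here, at this position, then, this swap of one seven-carbon group for another leaves the read-out within the usual scatter, which the earlier compounds could not show. No measurement shown here accounts for this result.

Still open, going by these compounds, is how the read-out would respond to a group on this nitrogen that carries an amine or a carboxylic acid. A longer chain ending in a phenyl ring is equally untested by the compounds shown.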